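Chloro to methyl on two indole cores: aromatase inhibition

The source may hold more compounds than are shown below. What is called first, only, known or untested is meant among the compounds shown, and "the series" means these compounds.

Measured compounds:
compound 1 `Clc1ccccc1-c1cc2ccccc2[nH]1`: 21.5%
compound 2 `Cc1ccccc1-c1cc2ccccc2[nH]1`: 27.1%
compound 3 `Clc1ccc2cc(-c3ccccc3)[nH]c2c1`: 13.6%

Of the compounds shown here, three have been tested in an assay on isolated protein for inhibition of Aromatase (Homo sapiens), read by fluorescence, using NADPH, with a stated time of 30 min, tested at 50 uM; on this read-out lower numbers stand for less inhibition and higher numbers for more inhibition at the one concentration tested (going by the name of the read-out). Compound 1 `Clc1ccccc1-c1cc2ccccc2[nH]1` gives 21.5% in this assay, and compound 2 `Cc1ccccc1-c1cc2ccccc2[nH]1` gives 27.1%. Compound 2 differs from compound 1 by the change methyl in place of chloro on an aromatic carbon and the step is a number 5.6 percentage points higher from compound 1 to compound 2 (within the scatter). Compound 3 `Clc1ccc2cc(-c3ccccc3)[nH]c2c1` gives 13.6% in this assay; compound 3 and compound 1 are built from the same atoms joined differently, and the difference between the two cores is not broken down here.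

Compound 4 `Cc1ccc2cc(-c3ccccc3)[nH]c2c1` has not yet been measured. It differs from compound 3 by methyl in place of chloro on an aromatic carbon. This is the same kind of change as that from compound 1 to compound 2, though not the same: in compound 2 the methyl sits on a six-membered aromatic ring of carbon only, ortho to a group of 9 heavy atoms, whereas in compound 4 it sits on a ring that is part of a fused or bridged system of two rings, meta to a fused ring and para to a fused ring. Within the data shown here, since the one measured instance of this kind of change, a number 5.6 percentage points higher from compound 1 to compound 2 (within the scatter), lay within the scatter, the step from compound 3 to compound 4 in this assay is expected to be small as well, estimated at a number 5.4 percentage points higher from compound 3 to compound 4 (within the scatter). Compound 4 is accordingly expected to give about 19% in this assay, estimated between 8% and 32%.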

Compound 4, a percentage reported as inhibition, at one concentration (the size of the read-out at that concentration, not a potency): 32.4%
Beside the measured number, compound 4's estimate is 13.4 percentage points below it; the measured number lies above the stated range.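

In this assay, methyl in place of chloro on an aromatic carbon of the second core gave a number 18.8 percentage points higher from compound 3 to compound 4 (beyond the scatter), and on the first core the same kind of change gave a number 5.6 percentage points higher from compound 1 to compound 2 (within the scatter). Both steps run in the same direction, but only the second lies beyond the scatter, and the gap between them is no larger than two such steps can show by chance, so these compounds give no ground for saying that the core alters the size of the change: the same change on two cores in this assay, a number 5.6 percentage points higher (within the scatter) from compound 1 to compound 2 and a number 18.8 percentage points higher (beyond the scatter) from compound 3 to compound 4, 13.2 percentage points apart, within the scatter of two such steps. Among these compounds, this does not show that the step carries over with a fixed size, since it rests on only two pairs, with the group at a different place in each, and it says nothing about why methyl and chloro differ or how either compound would behave across a range of concentrations.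

The compounds shown leave open how other groups at these same places would read, such as a methoxy, an amine, a carboxylic acid or a longer chain. They also leave open whether the step from chloro to methyl would run the same way on a third core.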